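Octyl to trifluoromethylphenoxy: stability of a tetrazole acid

The source may hold more compounds than are shown below. What is called first, only, known or untested is meant among the compounds shown, and "the series" means these compounds.

Of the compounds shown here, two have been measured in an ADME assay on S9 fraction from liver (Rattus norvegicus) for metabolic stability, read by LC-MS, using NADPH, with a stated time of 30 min; on this read-out lower numbers stand for a less stable compound and higher numbers for a more stable compound. Compound 1 `COC(=O)c1ccc(-c2nnn(CC(=O)C(C)Oc3ccc(Oc4ccc(C(F)(F)F)cc4)cc3)n2)cc1` gives 15%. Compound 2 `CCCCCCCCc1ccc(OC(C)C(=O)Cn2nnc(-c3ccc(C(=O)O)cc3)n2)cc1` gives 55%, the higher of the two numbers, and the gap to compound 1 is beyond the usual scatter. Compound 3 `CC(Oc1ccc(Oc2ccc(C(F)(F)F)cc2)cc1)C(=O)Cn1nnc(-c2ccc(C(=O)O)cc2)n1` differs from compound 2 by one change: 4-(trifluoromethyl)phenoxy in place of octyl on an aromatic carbon. Compound 1 and compound 3 share that trifluoromethylphenoxy group, so the low number of compound 1 weighs against a high expectation. The step from compound 2 to compound 3 is expected to be a decrease, a number 20 percentage points lower from compound 2 to compound 3 (beyond the scatter). Compound 3 is estimated at 35%, within 15% to 60%.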

Compound 3, percent of the compound remaining: 36%
Compound 3: the middle estimate sits 1 percentage points below what was measured; measured number inside the range.
By their numbers in this assay, from the lowest: compound 1; then compound 3; then compound 2.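

In this assay the aromatic carbon para to a large group proves sensitive to what it carries: 4-(trifluoromethyl)phenoxy in place of octyl gives a number 19 percentage points lower from compound 2 to compound 3 (beyond the scatter) on this read-out. With 4-(trifluoromethyl)phenoxy kept, hydrogen in place of methyl on the ester oxygen gives a number 21 percentage points higher from compound 1 to compound 3 (beyond the scatter) as well, so a second place on the molecule also moves the number. No measurement here explains either step. From the compounds shown here alone, whether a butyl chain or an unsubstituted phenoxy at the aromatic carbon would sit closer to octyl remains open. So does how an amide would compare with the free acid of compound 3 in this series.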